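Working notes on cytotoxicity: compound 1 to compound 3

This account rests on a few compounds, and the source may have more. Where it says the series, first, only, none or still open, it means among the compounds named here.

Measured so far:
compound 1, `CCc1nc(-c2ccc(OCCC(C)CCN3CCN(c4ccnc(N)c4)C3=O)cc2)no1`: > 100000 nM
compound 2, `CCO/N=C/c1ccc(OCCCCN2CCN(c3ccnc(N)c3)C2=O)cc1`: > 100000 nM

In an ADME assay on RD cells (Homo sapiens) for cytotoxicity, read by MTT assay, with a stated time of 24 h (a lower number here means that less compound is tolerated, a higher number that more compound is tolerated), compound 1 gives > 100000 nM, which is a limit of the assay and not a number. Compound 2 gives > 100000 nM in this assay, likewise a limit. Going by the values given here, compound 1 therefore stands at the limit of > 100000 nM in this assay, at which 2 of the 2 values shown sit; no measured step between the two compounds can be drawn, and no direction can be read from them.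

Compound 3, `CCONC(=O)c1ccc(OCCC(C)CCN2CCN(c3ccnc(N)c3)C2=O)cc1`, differs from compound 1 by ethoxycarbamoyl in place of 5-ethyl-1,2,4-oxadiazol-3-yl on an aromatic carbon, in words ethoxycarbamoyl in place of 5-ethyl-1,2,4-oxadiazol-3-yl on an aromatic carbon. With both measured values sitting at a limit, the expected step that the limit leaves unreadable from compound 1 to compound 3 is none beyond the scatter, and the reading is expected to fall again at the limit rather than as a number. Compound 3 is estimated at 150000 nM in this assay, with a range from 60000 nM to 400000 nM.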

Compound 3, half-maximal cytotoxic concentration: > 100000 nM
Compound 3: no number, only a limit; the forecaster's own chance of this, stated with the estimate: 80%; the middle value does not contradict the limit.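

Compound 3, like compound 1, sits at a limit and not at a number, so no step between the two can be read: the limit of > 100000 nM in this assay, at which 3 of the 3 values shown sit.

The compounds shown leave open what concentration lies behind these limits, and so whether ethoxycarbamoyl in place of 5-ethyl-1,2,4-oxadiazol-3-yl shifts cytotoxicity at all.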